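Methyl in Place of Chloro: An Expected Solubility Reading

The source may hold more compounds than are shown below. What is called first, only, known or untested is meant among the compounds shown, and "the series" means these compounds.

Compound 1 `N#Cc1cnc(NC(=O)CCCOc2cccc(C(F)(F)F)c2)s1` — in a physicochemical assay for solubility, read by nephelometry, in phosphate buffer, at pH 6.5 (on this read-out lower numbers stand for lower solubility and higher numbers for higher solubility), compound 1 reaches only a limit, < 1600 nM.
Compound 2 `CC(C)c1cnc(NC(=O)CCCOc2ccccc2)s1` — in this assay compound 2 reaches only a limit, < 1200 nM.
Compound 3 `O=C(CCCOc1ccccc1)Nc1ncc(Cl)s1` — in this assay compound 3 reaches only a limit, < 1200 nM.

Compound 3 stands at a limit of this assay rather than at a number, and the two other values shown are limits as well: the limit of < 1200 nM in this assay, at which 2 of the 3 values shown sit, and (the limit of < 1600 nM in this assay, at which 1 of the 3 values shown sits). Going by the values given here, the only step between measured compounds, a step that the two limits leave unreadable from compound 2 to compound 3, therefore has no readable size, since both of its ends are limits.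

Compound 4 `Cc1cnc(NC(=O)CCCOc2ccccc2)s1` differs from compound 3 in one place: methyl in place of chloro on an aromatic carbon. Among the compounds with values here, no measured step bears on this change with a readable size; the step from compound 2 to compound 3 touches the same place but cannot be read. With every value shown sitting at a limit, no direction beyond the scatter can be drawn for this assay.

Compound 4 is therefore expected to give about 800 nM in this assay, within a range from 200 nM to 3000 nM. The step that the limit leaves unreadable from compound 3 to compound 4 is expected to stay within the usual scatter, and compound 4 is expected most likely to be reported again only as a limit.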

Compound 4, solubility: < 1100 nM
Compound 4: a limit, no number (the forecaster's own chance of this, stated with the estimate: 75%); the middle value lies beyond the limit too.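

Compound 4 reaches only a limit in this assay, and neither its step from compound 2 nor its step from compound 3 can be read. Going by these compounds, whether methyl, chloro or isopropyl on the shared core makes any difference in this assay stays open.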